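A few compounds are considered here, and "the series" means these few. Any claim that something is new, unique, unknown or untested is made for them only; others in the source may bear on it.

Compound 1 `CO[C@@H]1CC=C2NN(c3c[nH]c4ccccc34)C(=O)CC[C@]2(c2ccccc2)O1` and compound 2 `CO[C@@H]1CC=C2NN(c3cc(Cl)cc(Cl)c3)C(=O)CC[C@]2(c2ccccc2)O1` share one core, while compound 3 `CO[C@@H]1CC=C2N(c3c[nH]c4ccccc34)C(=O)C[C@]2(c2ccccc2)O1` and the as yet unmeasured compound 4 `CO[C@@H]1CC=C2N(c3cc(Cl)cc(Cl)c3)C(=O)C[C@]2(c2ccccc2)O1` share another; the difference between the two cores is not broken down here. In a functional assay on DU-145 cells (Homo sapiens) for cytotoxicity, read by sulforhodamine B assay, with a stated time of 48 h (a lower number here means a stronger inhibitor, a higher number a weaker inhibitor), compound 1 gives 1130 nM and compound 2 gives 8460 nM. That change, (3,5-dichlorophenyl in place of 1H-indol-3-yl on an amide-type nitrogen in a ring), made a 7.5-fold higher number from compound 1 to compound 2 (0.87 log units; beyond the scatter). In this assay compound 3 gives 7330 nM. Compound 4 carries the same kind of change on its own core, (3,5-dichlorophenyl in place of 1H-indol-3-yl on an amide-type nitrogen in a ring); here the ring is five-membered with one nitrogen rather than seven-membered with two, the nitrogen is not next to a ring nitrogen, and the fused ring and the phenyl group sit two ring bonds away rather than three. Because compound 1 to compound 2 gave a 7.5-fold higher number from compound 1 to compound 2 (0.87 log units; beyond the scatter), the step to compound 4 is expected to be a 4.8-fold higher number from compound 3 to compound 4 (0.68 log units; beyond the scatter) in this assay. Compound 4 is therefore estimated at 35000 nM in this assay, between 12000 nM and 100000 nM.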

Compound 4, half-maximal inhibitory concentration: 8170 nM
The estimate for compound 4 lay 4.3-fold (0.63 log units) above the measured number; the measured number lies below the stated range.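

Putting 3,5-dichlorophenyl in place of 1H-indol-3-yl on the amide-type nitrogen gives a 1.1-fold higher number from compound 3 to compound 4 (0.05 log units; within the scatter) in this assay, so on this core the change has no readable effect. The size of the step did not carry over from one core to the other: the same change on two cores in this assay, a 7.5-fold higher number (0.87 log units; beyond the scatter) from compound 1 to compound 2 and a 1.1-fold higher number (0.05 log units; within the scatter) from compound 3 to compound 4, 6.7-fold (0.83 log units) apart, beyond the scatter of two such steps.
This shows that, in these two pairs, a step measured on one core was a poor guide to the step on the other, but it does not show which difference between the cores is responsible, and two pairs set no rule for other cores.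

Going by these compounds, whether a group such as an amine or a carboxylic acid on that nitrogen would give similar steps on both cores remains open. So does whether the gap between the steps would appear in other cell lines.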